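Swapping an Ethoxy for Chloro on a Pyrazine-Type Core

The source may hold more compounds than are shown below. What is called first, only, known or untested is meant among the compounds shown, and "the series" means these compounds.

Compound 1 `CCc1nc(-c2ccc(Cl)cc2Cl)c(CC)nc1NC(CC)CC` gives 4.1 nM in an assay on IMR-32 cells for displacement of a labelled ligand from corticotropin-releasing factor receptor 1 (Homo sapiens), read by scintillation counting, with a stated time of 2 h; a lower number here means a stronger inhibitor, a higher number a weaker inhibitor. Compound 2 `CCOc1nc(-c2ccc(Cl)cc2Cl)c(CC)nc1NC(CC)CC`, with an ethoxy in place of one ethyl, gives 151 nM, the highest of the three numbers, while compound 3 `CCc1nc(-c2ccc(Cl)cc2Cl)c(OC)nc1NC(CC)CC` gives 8 nM. Compound 4 `CCc1nc(NC(CC)CC)c(Cl)nc1-c1ccc(Cl)cc1Cl` is compound 2 with chloro in place of ethoxy on an aromatic carbon. The step of a 37-fold higher number from compound 1 to compound 2 (1.57 log units; beyond the scatter) shows that putting an ethoxy at this carbon weakened binding sharply, whereas a 2.0-fold higher number from compound 1 to compound 3 (0.29 log units; within the scatter) shows a methoxy elsewhere changing little. Removing the ethoxy again in favour of a small chloro is therefore expected to recover most of that loss, giving a large drop in the number. Compound 4 is estimated at 8 nM, within 2.5 nM to 30 nM, which corresponds to an expected step of a 19-fold lower number from compound 2 to compound 4 (1.28 log units; beyond the scatter).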

Compound 4, inhibition constant: 71 nM
Compound 4: the middle estimate sits 8.9-fold (0.95 log units) below what was measured; measured number above the stated range.
By their numbers in this assay, from the lowest: compounds 1 and 3 (each within the scatter of the next); then compound 4; then compound 2.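

Chloro in place of ethoxy gives only a 2.1-fold lower number from compound 2 to compound 4 (0.33 log units; beyond the scatter), whereas chloro in place of ethyl gives a 17-fold higher number from compound 1 to compound 4 (1.24 log units; beyond the scatter). At this carbon, ortho to the (pentan-3-yl)amino group, removing ethoxy for a group with fewer heavy atoms therefore recovers little, and of the three groups compared here, ethyl gives by far the lowest number. No supporting evidence is available to explain why ethyl and chloro differ so much. On these data alone, how a methyl group, a propyl chain or an amine would compare at this carbon remains open.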